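Swapping the ester group on the shared core

The source may hold more compounds than are shown below. What is called first, only, known or untested is meant among the compounds shown, and "the series" means these compounds.

Measured in a functional assay on DU-145 cells (Homo sapiens) for cytotoxicity, read by MTT assay; on this read-out lower numbers stand for stronger inhibition and higher numbers for weaker inhibition:
- compound 1 `CC[C@](C)(O)CC(=O)O[C@H](CC=C(C)C)C1=CC(=O)c2c(O)ccc(O)c2C1=O`: 20500 nM
- compound 2 `CC(=O)OC(C)CO[C@H](CC=C(C)C)C1=CC(=O)c2c(O)ccc(O)c2C1=O`: 16600 nM

Not yet measured: compound 3 `CC(C)=CC[C@@H](OC(=O)C1CCCCO1)C1=CC(=O)c2c(O)ccc(O)c2C1=O`.

Among the measured compounds shown here, compound 2 stands level with its only measured neighbour. Compound 3 carries (oxan-2-yl)carbonyl in place of 2-acetoxypropyl on an oxygen on a saturated carbon. For the measured compounds named here, the one measured step, a 1.2-fold lower number from compound 1 to compound 2 (0.09 log units; within the scatter), exchanged the group at this same place and stayed within the scatter. No step beyond the scatter is therefore expected in this assay, in either direction, though a single step is thin evidence. The expected step, a 1.1-fold lower number from compound 2 to compound 3 (0.04 log units; within the scatter), lies within the scatter. Compound 3 is estimated at 15000 nM, with an expected range of 6000 nM to 35000 nM.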

Compound 3, half-maximal inhibitory concentration: 24700 nM
Compound 3: middle estimate off by 1.6-fold (0.22 log units), on the low side, and the stated range covers the measured number.
By their numbers in this assay, from the lowest: compounds 2, 1 and 3 (each within the scatter of the next).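

In this assay, the step of a 1.5-fold higher number from compound 2 to compound 3 (0.17 log units; within the scatter) and the step of a 1.2-fold higher number from compound 1 to compound 3 (0.08 log units; within the scatter) show that a ring can enter at this oxygen without a step beyond the scatter. The six-membered non-aromatic ring of (oxan-2-yl)carbonyl thus sits level with both open-chain groups, so this place has so far tolerated every exchange shown. Nothing available explains this flat result.

From the compounds shown here alone, whether an amine or a carboxylic acid on this oxygen would give a step beyond the scatter remains open, as does the effect of a longer chain.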